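This account rests on a few compounds, and the source may have more. Where it says the series, first, only, none or still open, it means among the compounds named here.

Measured so far:
- compound 1 `CC1CC/C(=N\Nc2ccccc2F)c2ncc(C(=O)O)c(=O)n21`: > 1000 umol/kg
- compound 2 `CC1CC/C(=N\Nc2ccccc2Cl)c2ncc(C(=O)O)c(=O)n21`: > 1000 umol/kg

Both values are limits of a functional assay on the whole organism for inhibition, with Rattus norvegicus as the target (on this read-out lower numbers stand for an effect already at smaller amounts and higher numbers for an effect only at larger amounts of compound), not numbers. Compound 1 gives > 1000 umol/kg as a limit. Compound 2 likewise gives > 1000 umol/kg, also a limit. Among the measured compounds shown here, the one measured step, a step that the two limits leave unreadable from compound 1 to compound 2, therefore has no readable size because both compounds sit at the limit of > 1000 umol/kg in this assay, at which 2 of the 2 values shown sit. Compound 2 thus stands at the limit of this assay, with nothing to rank it against compound 1.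

Compound 3 `CC1CC/C(=N\Nc2ccccc2Br)c2ncc(C(=O)O)c(=O)n21` differs from compound 2 by bromo in place of chloro on an aromatic carbon. The step from compound 1 to compound 2, the only one measured, cannot guide the size of this step, since it was itself unreadable. The expectation is accordingly that compound 3 remains at or beyond the limit, that is, a step that the limit leaves unreadable from compound 2 to compound 3 is expected. Compound 3 is estimated at 1500 umol/kg, within a range from 500 umol/kg to 5000 umol/kg, and most likely this assay will again report only a limit for compound 3.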

Compound 3, dose for 50% inhibition: > 320 umol/kg
Compound 3: a limit, no number; the forecaster's own chance of this, stated with the estimate: 85%; the middle value is on the limit's open side.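

In this assay compound 3 gives > 320 umol/kg, a limit and not a number. Among the compounds shown here, no step among compound 1, compound 2 and compound 3 can therefore be read. The compounds shown leave open how fluoro, chloro and bromo on the aromatic carbon rank against one another.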